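This account rests on a few compounds, and the source may have more. Where it says the series, first, only, none or still open, it means among the compounds named here.

Compound 1 `Cc1ccc(OCC(=O)N(Cc2cccs2)c2ncco2)cc1`: 0.3 nM
Compound 2 `O=C(COc1ccc2c(c1)CCC2)N(Cc1cccs1)c1ccn[nH]1`: 0.001 nM

Both compounds were run in an assay on HEK293 cells for agonist activity at transient receptor potential cation channel subfamily M member 8 (Homo sapiens), read by fluorescence and calcium flux, with a stated time of 15 min; on this read-out lower numbers stand for an effect already at smaller amounts and higher numbers for an effect only at larger amounts of compound. Compound 1 stands highest of the two numbers with 0.3 nM. Compound 2 gives 0.001 nM, a gap from compound 1 that lies far beyond the usual scatter, but compound 2 differs from compound 1 in more than one place, so the two values alone do not say which part of the structure accounts for it.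

Compound 3 `Cc1ccc(OCC(=O)N(Cc2cccs2)c2ncccn2)cc1` has not yet been measured. It differs from compound 1 in one place: pyrimidin-2-yl in place of 1,3-oxazol-2-yl on an amide-type nitrogen. One aromatic ring with two hetero atoms gives way to another, six-membered rather than five-membered, on the same amide-type nitrogen. Within the data shown here, no measured pair shows this kind of change, so there is no direct guide. The step of a 1.7-fold higher number from compound 1 to compound 3 (0.22 log units; within the scatter) is expected to be small, either a modest rise in the number or none beyond the scatter. For compound 3 the estimated value is 0.5 nM, with a range from 0.1 nM to 3 nM.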

Compound 3, half-maximal effective concentration: 3700 nM
Compound 3: the middle estimate sits 7400-fold (3.87 log units) below what was measured; measured number outside the range, above it.
By their numbers in this assay, from the lowest: compound 2; then compound 1; then compound 3.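

In this assay, the group on the amide-type nitrogen proves decisive: pyrimidin-2-yl in place of 1,3-oxazol-2-yl gives a 12000-fold higher number from compound 1 to compound 3 (4.09 log units; beyond the scatter), a large step well beyond the usual scatter. Two aromatic rings that match in their counts of hydrogen-bond donors and acceptors, and that each carry two hetero atoms, are therefore not interchangeable at this position, something the earlier pair could not show. Nothing available here explains the jump.

Going by these compounds, the two rings differ in both size and hetero atoms, so it remains open which of these differences matters, and a 1,3-thiazol-2-yl or pyridin-2-yl group on the same nitrogen would help to separate them. On these data alone, it is also open whether this change would have a similar effect on the core of compound 2.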